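Removing One Hydroxy Group From Compound 2

The source may hold more compounds than are shown below. What is called first, only, known or untested is meant among the compounds shown, and "the series" means these compounds.

Compound 1 `Nc1ccc(-c2nc3ccccc3s2)cc1CO`: 6 nM
Compound 2 `Cc1cc(-c2nc3cc(O)ccc3s2)ccc1N`: 78700 nM

In a functional assay on MCF7 cells (Homo sapiens) for cytotoxicity (on this read-out higher numbers stand for weaker inhibition and lower numbers for stronger inhibition), compound 2 gives 78700 nM, the higher of the two numbers and far beyond the scatter from compound 1. Compound 3 `Cc1cc(-c2nc3ccccc3s2)ccc1N` differs from compound 2 in one place: hydrogen in place of hydroxy on an aromatic carbon, with hydrogen in place of hydroxy on an aromatic carbon. Compound 1 also has hydrogen at that place and gives 6 nM. A large fall in the number, meaning stronger inhibition, is therefore expected, an estimated 7900-fold lower number from compound 2 to compound 3 (3.90 log units; beyond the scatter). For compound 3 the expected value is 10 nM, within an estimated range of 0.8 nM to 200 nM.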

Compound 3, half-maximal inhibitory concentration: < 1 nM
Compound 3 ended at the assay's limit; the forecaster's own chance of this, stated with the estimate: 10%; middle value at least 10-fold (1.00 log units) from the limit.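

In this assay compound 3 gives < 1 nM, which is a limit of the assay and not a number. Swapping hydroxy for hydrogen on this aromatic carbon gives an at least 78000-fold lower number from compound 2 to compound 3 (4.89 log units; beyond the scatter), so this single position separates a very weak compound from a very strong one. Hydrogen in place of hydroxy on the saturated chain carbon, at a different place in the molecule, gives a much smaller but still real change: an at least 6.0-fold lower number from compound 1 to compound 3 (0.77 log units; beyond the scatter). From the compounds shown here alone, the true value of compound 3 remains open, so both steps could be larger. Going by these compounds, how a methoxy group, an amine or a fluorine atom on that aromatic carbon would behave also remains open.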